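Adding a Methyl to Compound 2's Hydroxy Group

This account rests on a few compounds, and the source may have more. Where it says the series, first, only, none or still open, it means among the compounds named here.

Compound 1 `COc1c(O)cc2cc1C[C@H](C)C[C@H](OC)[C@H](O)[C@@H](C)/C=C(\C)C[C@H](OC(N)=O)[C@@H](OC)CC/C=C(\C)C(=O)N2`: 2340 nM
Compound 2 `COc1ccc([C@H]2c3cccc(c3O)NC(=O)/C(C)=C/C=C\[C@H](OC)[C@@H](OC(N)=O)/C(C)=C/[C@H](C)[C@@H](O)[C@@H](OC)C[C@@H]2C)cc1`: 470 nM

In a functional assay on A2780 cells (Homo sapiens) for antiproliferative activity, read by MTT assay, with a stated time of 96 h (a lower number here means a stronger inhibitor, a higher number a weaker inhibitor), compound 2 has the lower of the two numbers, and its gap to compound 1 lies beyond the usual scatter. That makes compound 2 the stronger inhibitor of this measured pair.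

Compound 3 `COc1ccc([C@H]2c3cccc(c3O)NC(=O)/C(C)=C/C=C\[C@H](OC)[C@@H](OC(N)=O)/C(C)=C/[C@H](C)[C@@H](OC)[C@@H](OC)C[C@@H]2C)cc1` differs from compound 2 in one place: methyl in place of hydrogen on an oxygen on a saturated carbon. Here methyl takes the place of hydrogen on an oxygen on a saturated carbon, so a hydroxy becomes a methoxy.

Among the compounds with values here, no measured pair shows this change, so the forecast starts from compound 2 at 470 nM and remains uncertain. A modest move toward a weaker inhibitor is expected in this assay, with the estimated step being a 1.7-fold higher number from compound 2 to compound 3 (0.23 log units; within the scatter). The expected value for compound 3 is 800 nM, within an estimated range of 200 nM to 3000 nM.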

Compound 3, half-maximal inhibitory concentration: 2380 nM
Estimate against measurement, compound 3: 3.0-fold (0.47 log units) below; measured number inside the range.
By their numbers in this assay, from the lowest: compound 2; then compounds 1 and 3 (each within the scatter of the next).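

Turning the hydroxy into a methoxy on this saturated carbon gives a 5.1-fold higher number from compound 2 to compound 3 (0.70 log units; beyond the scatter) in this assay and is the first direct test of this position. Compounds 1 and 2 differ in more than one place, so they could not show how this oxygen responds to a single small change. The new pair shows that, in this assay, the hydrogen on this oxygen cannot be replaced by methyl without a change beyond the usual scatter, although no data here speak to why the number rises.

The compounds shown leave open whether a larger ether such as ethoxy would move the number further. They also leave open how an amine or an acetate ester would compare at this same place.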